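This account rests on a few compounds, and the source may have more. Where it says the series, first, only, none or still open, it means among the compounds named here.

The study compares four sulfonamides. Compound 1 `O=[N+]([O-])c1cccc(NS(=O)(=O)c2ccc(Cl)cc2)c1` and compound 2 `O=[N+]([O-])c1cccc(NS(=O)(=O)c2ccc(Br)cc2)c1` share one core; compound 3 `O=S(=O)(Nc1ccc(Cl)cc1)c1ccc(Cl)cc1` and compound 4 `O=S(=O)(Nc1ccc(Cl)cc1)c1ccc(Br)cc1` share another. How the core of compound 3 differs from that of compound 1 is not broken down here.

In an ADME assay, compound 1 gives 7.51, and compound 2 gives 7.42. The difference between them is bromo in place of chloro on an aromatic carbon, and it produced a number 0.09 log units lower from compound 1 to compound 2 (within the scatter). In this assay compound 3 gives 8.3, the highest of the three measured numbers; both compound 1 and compound 2 lie lower by more than the usual scatter.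

Compound 4 is not yet measured. It differs from compound 3 by bromo in place of chloro on an aromatic carbon, which is the same change as that from compound 1 to compound 2, made at the same kind of place. Because the earlier step was a number 0.09 log units lower from compound 1 to compound 2 (within the scatter), a step of the same small size is expected here, namely a number 0.09 log units lower from compound 3 to compound 4 (within the scatter). On that basis compound 4 is estimated to give 8.21 in this assay, with the likely range from 7.9 to 8.5.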

Compound 4, acid dissociation constant: 8.24
Beside the measured number, compound 4's estimate is 0.03 log units below it; the measured number falls inside the stated range.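

In this assay, bromo in place of chloro on an aromatic carbon gave a number 0.06 log units lower from compound 3 to compound 4 (within the scatter). Set beside the earlier step, the change reads alike on the two cores: the same change on two cores in this assay, a number 0.09 log units lower (within the scatter) from compound 1 to compound 2 and a number 0.06 log units lower (within the scatter) from compound 3 to compound 4, 0.03 log units apart, within the scatter of two such steps. Within these two pairs, then, the small step seen on the core of compound 1 carried over to the core of compound 3, but neither step stands clear of the scatter, so the data do not fix a direction for the swap, and two pairs do not show that it would stay this small on any other core.

The compounds shown leave open how a fluoro group, a methoxy group or a carboxylic acid would read in this assay at the same kind of place. They also leave open whether bromo for chloro would stay as small on a core carrying an amine or a nitrile.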